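The source may hold more compounds than are shown below. What is called first, only, known or untested is meant among the compounds shown, and "the series" means these compounds.

Compound 1 `CC1=C(C(=O)CC(C)C)C(c2ccco2)NC(=O)N1`: 16%
Compound 2 `CC1=C(C(=O)CC(C)C)C(c2cccs2)NC(=O)N1`: 19%
Compound 3 `CCN(CC)C(=O)C1=C(C)NC(=O)NC1c1ccco1`: 11%

All three were measured in an assay on membranes from CHO cells for displacement of a labelled ligand from adenosine receptor A1 (Homo sapiens), read by scintillation counting, with a stated time of 60 min, tested at 1 uM; on this read-out lower numbers stand for less inhibition and higher numbers for more inhibition at the one concentration tested (going by the name of the read-out). On the numbers shown, compound 1 stands second highest of the three. Its nearest neighbour is compound 2, reached by a number 3 percentage points higher from compound 1 to compound 2 (within the scatter), with thiophen-2-yl in place of furan-2-yl on a saturated ring carbon. Its furthest neighbour is compound 3, reached by a number 5 percentage points lower from compound 1 to compound 3 (within the scatter), with diethylamino in place of isobutyl on a carbonyl carbon. Both steps lie within the scatter, so neither change can be said to have moved the read-out.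

Compound 4 `CC1=C(c2ncc(C)o2)C(c2ccco2)NC(=O)N1` has not yet been measured in this assay. It differs from compound 1 as follows: 5-methyl-1,3-oxazol-2-yl in place of isobutylcarbonyl on a double-bonded ring carbon. Among the compounds with values here, of the measured steps, only one alters the group built on the carbonyl carbon, and that step, a number 5 percentage points lower from compound 1 to compound 3 (within the scatter), stayed within the scatter. Within the data shown here, the change in compound 4 removes the carbonyl carbon altogether, so no measured step reproduces it; the other step, a number 3 percentage points higher from compound 1 to compound 2 (within the scatter), concerns the saturated ring carbon and gives no guidance here. With the shared core otherwise unchanged, no shift beyond the scatter is expected in this assay.

In this assay compound 4 is therefore estimated to give about 15%, within a range from 0% to 35%. The expected step is a number 1 percentage points lower from compound 1 to compound 4 (within the scatter), judged to fall within the scatter.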

Compound 4, a percentage reported as inhibition, at one concentration (the size of the read-out at that concentration, not a potency): 27%
Beside the measured number, compound 4's estimate is 12 percentage points below it, and the stated range covers the measured number.
By their numbers in this assay, from the lowest: compounds 3, 1, 2 and 4 (each within the scatter of the next, the first and the last beyond it).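

In this assay, within the data shown here, the double-bonded ring carbon is the first place where a single change passes the scatter: 5-methyl-1,3-oxazol-2-yl in place of isobutylcarbonyl gives a number 11 percentage points higher from compound 1 to compound 4 (beyond the scatter) and so shows that this position can move the read-out. The earlier change on this substituent, a number 5 percentage points lower from compound 1 to compound 3 (within the scatter), kept the carbonyl carbon and replaced only the isobutyl, whereas this one removes the carbonyl and brings in a five-membered aromatic ring with the same number of heavy atoms as the group that leaves. Nothing available explains why the read-out rises with this exchange.

The compounds shown leave open whether the step belongs to the ring as such or to its methyl group, which a plain 1,3-oxazol-2-yl or a phenyl group at this position would help to separate. From the compounds shown here alone, it also remains open whether the same exchange would carry over to the thiophen-2-yl compound, and a reading at one concentration gives no potency for any of them.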